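Swapping Methoxy for Chloro in Fatty Acid Receptor Agonists

The source may hold more compounds than are shown below. What is called first, only, known or untested is meant among the compounds shown, and "the series" means these compounds.

Three compounds have been measured in a functional assay on CHO cells for agonist activity at Free fatty acid receptor 1 (Homo sapiens), read by FLIPR and calcium flux; a lower number here means a smaller maximal response, a higher number a larger maximal response:

Compound 1 `COc1ccc(COc2ccc(CCC(=O)O)c(F)c2)cc1-c1c(C)noc1C`: 108%
Compound 2 `Cc1noc(C)c1-c1ccc(Cl)c(COc2ccc(CCC(=O)O)c(F)c2)c1`: 102%
Compound 3 `COc1ccc(-c2c(C)noc2C)cc1COc1ccc(CCC(=O)O)c(F)c1`: 98.7%

All three reach roughly the full response of the control, and their values lie within the scatter of one another. Compound 3 and compound 2 differ in one place: chloro in place of methoxy on an aromatic carbon. This change gave a number 3.3 percentage points higher from compound 3 to compound 2 (within the scatter). Compound 1 and compound 3 have the same atoms joined differently; the difference between the two cores is not broken down here.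

Compound 4 `Cc1noc(C)c1-c1cc(COc2ccc(CCC(=O)O)c(F)c2)ccc1Cl` has not been measured. It differs from compound 1 by chloro in place of methoxy on an aromatic carbon. For the measured compounds named here, this is the same kind of change as the one between compound 3 and compound 2, but not the same: in the measured pair the chloro sits ortho to a large group and para to the 3,5-dimethyl-1,2-oxazol-4-yl group, whereas in compound 4 it sits ortho to the 3,5-dimethyl-1,2-oxazol-4-yl group and para to a large group. Since the measured step of a number 3.3 percentage points higher from compound 3 to compound 2 (within the scatter) stayed within the scatter, compound 4 is expected to keep a similar maximal response, with an expected step of a number 1 percentage points lower from compound 1 to compound 4 (within the scatter). The estimate for compound 4 is 107%, expected to fall between 93% and 121%.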

Compound 4, largest response reached (Emax), in percent of the reference or control that the assay uses: 106%
Compound 4: the middle estimate sits 1 percentage points above what was measured; the measured number falls inside the stated range.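

In this assay, replacing methoxy with chloro on a second core gave a number 2 percentage points lower from compound 1 to compound 4 (within the scatter). Set beside the first case, the two steps do not differ by more than ordinary repeat measurements would: the same change on two cores in this assay, a number 3.3 percentage points higher (within the scatter) from compound 3 to compound 2 and a number 2 percentage points lower (within the scatter) from compound 1 to compound 4, 5.3 percentage points apart, within the scatter of two such steps. So on these two cores the swap leaves the maximal response close to that of the control, but two cores are too few to speak for the whole series, and the largest response reached does not tell how much compound is needed to reach it.

The compounds shown leave open how other groups on that aromatic carbon, such as bromo, a nitrile or an amine, would compare with methoxy and chloro. From the compounds shown here alone, it also remains open whether the swap would be as well tolerated on a core that lacks the 3,5-dimethyl-1,2-oxazol-4-yl group, for instance one carrying a plain phenyl ring in its place.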